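This account rests on a few compounds, and the source may have more. Where it says the series, first, only, none or still open, it means among the compounds named here.

Measured compounds in the series:

- compound 1 `COc1cc(OC)c(/C=C/S(=O)(=O)Cc2ccc(OC)c(N)c2)c(OC)c1`: 2.5 nM
- compound 2 `COc1ccc(CS(=O)(=O)/C=C/c2c(OC)cc(OCCCC(=O)O)cc2OC)cc1N`: 20000 nM

In a functional assay on K562 cells (Homo sapiens) for cytotoxicity, read by trypan blue exclusion, with a stated time of 96 h (on this read-out lower numbers stand for stronger inhibition and higher numbers for weaker inhibition), compound 1 gives the lowest of the two numbers; its nearest neighbour is compound 2, reached by an 8000-fold higher number from compound 1 to compound 2 (3.90 log units; beyond the scatter). Among the measured compounds shown here, that step, 2-carboxyethyl in place of hydrogen on a saturated chain carbon bound to an oxygen on an aromatic ring, is the only measured step, and it is large and beyond the scatter.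

Compound 3 `COc1cc(OC)c(/C=C/S(=O)(=O)Cc2ccc(OC)c(NC(C(=O)O)c3ccccc3)c2)c(OC)c1` is not yet measured in this assay. It differs from compound 1 by carboxy(phenyl)methyl in place of hydrogen on a nitrogen on an aromatic ring. For the measured compounds named here, the change sits on the nitrogen rather than on the chain oxygen, so the one measured step does not map onto it directly; still, the step from compound 1 to compound 2 is the only guide, and it also brought in a carboxylic acid with a loss in this assay of an 8000-fold higher number from compound 1 to compound 2 (3.90 log units; beyond the scatter). A large rise in the number is therefore expected for compound 3, though with wide uncertainty, because the place of the change differs from that in an 8000-fold higher number from compound 1 to compound 2 (3.90 log units; beyond the scatter). Compound 3 is estimated at 2000 nM, range 100 nM to 30000 nM, which would be a step of an 800-fold higher number from compound 1 to compound 3 (2.90 log units; beyond the scatter).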

Compound 3, half-maximal inhibitory concentration: 15 nM
Compound 3: the middle estimate sits 130-fold (2.12 log units) above what was measured; measured number outside the range, below it.
By their numbers in this assay, from the lowest: compound 1; then compound 3; then compound 2.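

In this assay, the nitrogen on an aromatic ring carries carboxy(phenyl)methyl in place of hydrogen at a cost of only a 6.0-fold higher number from compound 1 to compound 3 (0.78 log units; beyond the scatter) and so takes an entering group of 10 heavy atoms, including a six-membered aromatic ring, while compound 3 stays in the low nanomolar range. The earlier step of an 8000-fold higher number from compound 1 to compound 2 (3.90 log units; beyond the scatter) also brought in a carboxylic acid, so a carboxylic acid in the molecule does not by itself go with a loss of that size: the two steps from compound 1 differ widely, with the acid placed on different groups at different sites. The step to compound 3 is still beyond the scatter, so the nitrogen substituent is not without effect in this read-out.

The shown compounds leave open whether the phenyl ring or the carboxylic acid sets the size of this step; carboxymethyl or benzyl on the same nitrogen would separate the two. Also open, going by these compounds, is how a methyl ester or an amide in place of the carboxylic acid would read at either site. No evidence at hand bears on the difference between the two steps.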